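Swapping Bromine for Phenyl on an Aryl Urea

The compounds below may be only part of what the source reports. "The series", "measured", "known", "first", "only" and "open" are said of these compounds alone.

Measured compounds:
compound 1 `CCN1CCc2c(sc(NC(=O)Nc3ccc(Br)cc3)c2C(N)=O)C1`, 3130 nM
compound 2 `CCN1CCc2c(sc(NC(=O)NCC3CCCO3)c2C(N)=O)C1`, > 25000 nM
compound 3 `CCN1CCc2c(sc(NC(=O)c3ccccc3)c2C(N)=O)C1`, > 25000 nM

Of the compounds shown here, three sharing one core have been tested in a functional assay (strain AB) with Danio rerio as the target, read by microscopy, with a stated time of 1 h; on this read-out higher numbers stand for an effect only at larger amounts of compound and lower numbers for an effect already at smaller amounts. For the measured compounds named here, compound 1 gives 3130 nM, the only actual number among the three. For compound 2 the result of > 25000 nM is a limit of the assay, not a number. For compound 3 the result of > 25000 nM is likewise a limit. The two measured steps both start from compound 1 and both go in the same direction: an at least 7.9-fold higher number from compound 1 to compound 2 (0.90 log units; beyond the scatter), and an at least 7.9-fold higher number from compound 1 to compound 3 (0.90 log units; beyond the scatter). In both cases the 4-bromophenyl urea is replaced by something else and the effect weakens; the shared feature is the limit of > 25000 nM in this assay, at which 2 of the 3 values shown sit.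

Compound 4 `CCN1CCc2c(sc(NC(=O)Nc3ccc(-c4ccccc4)cc3)c2C(N)=O)C1` keeps the aryl urea of compound 1 and changes only the group on the ring: phenyl in place of bromo on an aromatic carbon. Neither measured step bears directly on this change, since both alter the urea or the aryl group itself rather than its substituent. With the aryl urea retained, the expectation for compound 4 is a step of a 1.3-fold lower number from compound 1 to compound 4 (0.10 log units; within the scatter), roughly within the scatter. Compound 4 is therefore estimated at 2500 nM, with a range from 700 nM to 12000 nM.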

Compound 4, half-maximal effective concentration: 3390 nM
For compound 4 the middle estimate is 1.4-fold (0.13 log units) below the measured one, and the stated range covers the measured number.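

In this assay, replacing bromo (1 heavy atom) with phenyl (6 heavy atoms) gives a 1.1-fold higher number from compound 1 to compound 4 (0.03 log units; within the scatter). For the compounds shown here, this place on the aromatic ring, para to a large group, therefore takes a much larger group with no readable change in the effect, which the earlier compounds could not show, since their steps altered the urea or its aryl group rather than the group on that ring. Nothing in the data shown explains why bromo and phenyl read alike here.

Among the compounds shown, only bromo and phenyl sit at this place, so it remains open how an amine, a carboxylic acid or a longer chain would behave there. Also open, on these data alone, is whether any group at this place can move the effect beyond the scatter, in either direction.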